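The source may hold more compounds than are shown below. What is called first, only, known or untested is meant among the compounds shown, and "the series" means these compounds.

Measured so far in a functional assay on MIA PaCa-2 cells (Homo sapiens) for inhibition, read by MTT assay, with a stated time of 3 days; a lower number here means a stronger inhibitor, a higher number a weaker inhibitor:
compound 1 `CCN(CC)S(=O)(=O)c1ccc(S(=O)(=O)N2CCC[C@@H](C(=O)N3CCC(F)(F)CC3)C2)cc1` gives 19 nM
compound 2 `O=C([C@@H]1CCCN(S(=O)(=O)c2ccc(S(=O)(=O)C3CCC3)cc2)C1)N1CCC(F)(F)CC1` gives 12.6 nM

For the measured compounds named here, compound 1 has the highest of the two numbers so far, and its nearest neighbour, compound 2, differs by a 1.5-fold lower number from compound 1 to compound 2 (0.18 log units; within the scatter), a step that lies within the scatter. Compound 3 `CCN(CC)S(=O)(=O)c1ccc(S(=O)(=O)N2CCC[C@@H](C(=O)N3CCS(=O)(=O)CC3)C2)cc1` keeps the whole of compound 1 except at the amide end, where the change is 1,1-dioxothiomorpholin-4-yl in place of 4,4-difluoropiperidin-1-yl on a carbonyl carbon. Going by the values given here, no measured step touches this position: the only step known, from compound 1 to compound 2, sits on a sulfonyl sulfur at the far side of the shared core and was small. There is therefore no evidence for a shift in either direction, and the expected step of a 1.3-fold higher number from compound 1 to compound 3 (0.12 log units; within the scatter) is none beyond the scatter, with a wider uncertainty than a repeated measurement would carry. Compound 3 is expected to give about 25 nM, in a range from 8 nM to 80 nM.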

Compound 3, half-maximal inhibitory concentration: 220 nM
Estimate against measurement, compound 3: 8.8-fold (0.94 log units) below, outside the stated range (above it).
By their numbers in this assay, from the lowest: compounds 2 and 1 (each within the scatter of the next); then compound 3.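

In this assay, for the compounds shown here, the amide end of the molecule proves sensitive, which the earlier pair could not show, as its only step lay on a sulfonyl sulfur elsewhere in the molecule. Here, 1,1-dioxothiomorpholin-4-yl in place of 4,4-difluoropiperidin-1-yl on the carbonyl carbon gives a large step (a 12-fold higher number from compound 1 to compound 3 (1.06 log units; beyond the scatter)), even though both rings are six-membered and hold 8 heavy atoms. The entering group holds 2 hydrogen-bond acceptors and the leaving group none, but no measurement here ties the step to that difference or to any other feature.

On these data alone, whether the step follows from losing the fluorines or from gaining the ring sulfonyl stays open, and a plain piperidine or a morpholine on this carbonyl would help separate the two. Also open, as far as these compounds go, is whether the same change has an equally large effect with cyclobutyl on the sulfonyl sulfur, as in compound 2.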